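The source may report more compounds than this note shows. Statements on the series, on what has been measured and on what is new or still open speak of the compounds shown alone.

Compound 1 `CCc1c(SC)nc2nc(C(=O)c3ccccc3)cn2c1C`: 2 mg/kg
Compound 2 `CCCc1c(OC)nc2nc(C(=O)c3ccccc3)cn2c1CC`: 10 mg/kg
Compound 3 `CCCCc1c(OC)nc2nc(C(=O)c3ccccc3)cn2c1C`: 2 mg/kg

In a functional assay on the whole organism with Rattus norvegicus as the target (on this read-out higher numbers stand for an effect only at larger amounts of compound and lower numbers for an effect already at smaller amounts), compound 2 stands at the highest of the three numbers, 10 mg/kg. Compound 1 gives 2 mg/kg, and compound 3 gives 2 mg/kg; the gap from compound 2 to each of them lies beyond the scatter, so compound 2 is the one of the three that shows its effect only at a larger amount. Within the data shown here, no two of the measured compounds differ in a single place, so no measured step is available to lean on.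

Compound 4 `C=CCc1c(OC)nc2nc(C(=O)c3ccccc3)cn2c1CC` is the next compound to be tested. It differs from compound 2 as follows: vinyl in place of ethyl on a saturated chain carbon bound to an aromatic carbon. With no measured step of this kind in hand, only a modest move is expected; a step of a 1.7-fold lower number from compound 2 to compound 4 (0.22 log units; within the scatter) is estimated, pointing toward a lower number but possibly remaining within the scatter. Compound 4 is therefore expected to give 6 mg/kg, with a range from 2 mg/kg to 15 mg/kg.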

Compound 4, minimum effective dose: 10 mg/kg
Estimate against measurement, compound 4: 1.7-fold (0.22 log units) below; the measured number falls inside the stated range.
By their numbers in this assay, from the lowest: compounds 1 and 3 (each within the scatter of the next); then compounds 2 and 4 (each within the scatter of the next).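

In this assay, among these compounds, allyl in place of propyl, which is vinyl in place of ethyl on a saturated chain carbon bound to an aromatic carbon, gives no change at the digits printed from compound 2 to compound 4 (within the scatter) and so provides the first comparison in which only one place differs. Among the compounds shown here, at this place, then, the added double bond outside the aromatic rings leaves the minimum effective dose unchanged at the digits printed, something the earlier compounds, which all differed in more than one place, could not show. No measurement shown offers an explanation for this outcome.

As far as these compounds go, whether a longer chain such as pentyl, or a phenyl group, at this place would shift the number remains open. From the compounds shown here alone, it is also open whether propyl to allyl would give the same result in a compound carrying methylthio instead of methoxy.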